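This account rests on a few compounds, and the source may have more. Where it says the series, first, only, none or still open, it means among the compounds named here.

In an ADME assay on HepG2 cells (Homo sapiens) for cytotoxicity (on this read-out lower numbers stand for an effect already at smaller amounts and higher numbers for an effect only at larger amounts of compound), compound 1 `Cc1ccc(S(=O)(=O)N[C@@H](CC(=O)NC(C)(C)C)C(=O)NCCNC(=O)c2ccc(F)cc2)cc1` gives > 11000 nM as a limit of the assay. Compound 2 `Cc1ccc(S(=O)(=O)N[C@@H](CC(=O)NC(C)(C)C)C(=O)NCCNC(=O)c2cccc(C#N)c2)cc1` gives > 11000 nM as a limit too. Compound 3 `Cc1ccc(S(=O)(=O)N[C@@H](CC(=O)NC(C)(C)C)C(=O)NCCNC(=O)c2cc(Cl)ccc2Cl)cc1` gives > 11000 nM as a limit as well. The series therefore rests at the limit of > 11000 nM in this assay, at which 3 of the 3 values shown sit, and has no number to place compound 3. Compound 4 `Cc1ccc(S(=O)(=O)N[C@@H](CC(=O)NC(C)(C)C)C(=O)NCCNC(=O)NCc2ccccc2)cc1` carries benzylamino in place of 2,5-dichlorophenyl on a carbonyl carbon and keeps the shared core. Three changes at that place bear on this: a step that the two limits leave unreadable from compound 1 to compound 2 and a step that the two limits leave unreadable from compound 1 to compound 3 and a step that the two limits leave unreadable from compound 2 to compound 3 give no readable size. No step beyond the scatter is therefore expected in this assay in either direction. The expected change is a step that the limit leaves unreadable from compound 3 to compound 4 and no more. Compound 4 is estimated at 15000 nM with an expected range from 8000 nM to 40000 nM and may well return only a limit.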

Compound 4, half-maximal effective concentration: > 11000 nM
Compound 4: only a limit was reported (the forecaster's own chance of this, stated with the estimate: 85%); the middle value lies beyond the limit too.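

Going by these compounds alone, compound 4 also gives only a limit, so no step from compound 1, compound 2 or compound 3 to compound 4 can be read in this assay: the limit of > 11000 nM in this assay, at which 4 of the 4 values shown sit. The compounds shown leave open whether swapping the group on the carbonyl carbon changes this read-out at all.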